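Amide chain variants: notes on chromatographic lipophilicity

The source may report more compounds than this note shows. Statements on the series, on what has been measured and on what is new or still open speak of the compounds shown alone.

Compound 1 `CCC(=O)NCCCO[C@H]1[C@H](C)[C@@H](O[C@@H]2O[C@H](C)C[C@H](N(C)C)[C@H]2O)[C@](C)(O)C[C@@H](C)CN(C)[C@H](C)[C@@H](O)[C@](C)(O)[C@@H](CC)OC(=O)[C@@H]1C` carries a propanoylamino group on its side chain. Among the compounds with values here, in a physicochemical assay for lipophilicity, read by HPLC, measured as chromatographic lipophilicity, at pH 7.4 (a higher number here means a more lipophilic compound, a lower number a more polar compound), compound 1 gives 1.6, the lowest of the three numbers measured so far. Compound 3 `CC[C@H]1OC(=O)[C@H](C)[C@@H](O[C@H]2C[C@@](C)(OC)[C@@H](O)[C@H](C)O2)[C@H](C)[C@@H](O[C@@H]2O[C@H](C)C[C@H](N(C)C)[C@H]2O)[C@](C)(OC)C[C@@H](C)C(=O)[C@H](C)[C@@H](OCCCNC(C)=O)[C@]1(C)O` gives 2.72 in this assay, the nearest of the other values and beyond the scatter from compound 1. Compound 2 `CCCCCCCC(=O)NCCCO[C@H]1[C@H](C)O[C@@H](O[C@H]2[C@H](C)[C@@H](O[C@@H]3O[C@H](C)C[C@H](N(C)C)[C@H]3O)[C@](C)(OC)C[C@@H](C)C(=O)[C@H](C)[C@@H](O)[C@](C)(O)[C@@H](CC)OC(=O)[C@@H]2C)C[C@@]1(C)OC` gives 6.02 in this assay, the furthest value, also beyond the scatter. Within the data shown here, compounds 2 and 3 differ from compound 1 in more than one place, so their values show only where compound 1 sits relative to them and give no single-change step.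

Compound 4 `CC[C@H]1OC(=O)[C@H](C)[C@@H](OCCCNC(=O)C2CCC2)[C@H](C)[C@@H](O[C@@H]2O[C@H](C)C[C@H](N(C)C)[C@H]2O)[C@](C)(O)C[C@@H](C)CN(C)[C@H](C)[C@@H](O)[C@]1(C)O` differs from compound 1 in one place: cyclobutyl in place of ethyl on a carbonyl carbon. Among the measured compounds shown here, no pair of measured compounds differing in one place is available, so the size of this step cannot be read from a measurement. The estimated step is a number 0.70 log units higher from compound 1 to compound 4 (beyond the scatter), a rise in this assay expected to lie beyond the scatter but well short of the gap to compound 2. Compound 4 is thus expected to read 2.3 in this assay, with a range from 1.8 to 2.8.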

Compound 4, distribution coefficient: 1.78
Beside the measured number, compound 4's estimate is 0.52 log units above it; the whole stated range lies above it.
By their numbers in this assay, from the lowest: compounds 1 and 4 (each within the scatter of the next); then compound 3; then compound 2.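

At this position, on a carbonyl carbon whose other neighbour is an amide-type nitrogen, the series now has its first step read from two measured compounds: cyclobutyl in place of ethyl gives a number 0.18 log units higher from compound 1 to compound 4 (within the scatter) in this assay on the core of compound 1. Replacing the open ethyl with a four-membered ring of carbon only, with no hydrogen-bond donor or acceptor leaving or entering, therefore does not separate the two compounds in this assay here. Compound 2 and compound 3 could not give this reading. Each of them differs from compound 1 in more than one place. No measured information on the origin of this result is available.

Still open, on these data alone, is whether a cyclohexyl or phenyl group, or a chain ending in an amine or a carboxylic acid, on this carbonyl carbon would give a step beyond the scatter. Within the data shown here, the effect of chain length at this carbonyl on the core of compound 1 also remains unknown, as no single-change step to compound 2 or compound 3 can be read.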